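The source may hold more compounds than are shown below. What is called first, only, known or untested is meant among the compounds shown, and "the series" means these compounds.

Compound 1 `CCCCCOC(=O)C(C)(C)C(c1ccc(Nc2ccc3ccccc3c2)cc1)n1ccnc1` and compound 2 `CC(C)OC(=O)C(C)(C)C(c1ccc(Nc2ccc3ccccc3c2)cc1)n1ccnc1` share the same core and differ only in the ester group. In an assay on isolated protein for inhibition of cytochrome P450 26A1 (Homo sapiens), read by scintillation counting (on this read-out higher numbers stand for weaker inhibition and lower numbers for stronger inhibition), compound 1 gives 140 nM, while compound 2 gives 290 nM. Among the measured compounds shown here, the single measured step, a 2.1-fold higher number from compound 1 to compound 2 (0.32 log units; beyond the scatter), is the only comparison available, and on it compound 2 stands as the highest of the two numbers, with compound 1 as its nearest neighbour.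

Compound 3 `CC(C)NC(=O)C(C)(C)C(c1ccc(Nc2ccc3ccccc3c2)cc1)n1ccnc1` is the next compound, and it differs from compound 2 by isopropylamino in place of isopropoxy on a carbonyl carbon. For the measured compounds named here, no measured step bears directly on this exchange: the one step known, a 2.1-fold higher number from compound 1 to compound 2 (0.32 log units; beyond the scatter), swaps one group on the oxygen for another and leaves the ester itself in place, so it says nothing about replacing the isopropoxy by isopropylamino. With no guide in the data, the expectation for this assay is a step of no more than the usual scatter in either direction. Compound 3 is therefore estimated at 300 nM, within a range of 100 nM to 900 nM. That estimate corresponds to an expected step of a 1.0-fold higher number from compound 2 to compound 3 (0.01 log units; within the scatter).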

Compound 3, half-maximal inhibitory concentration: 120 nM
Beside the measured number, compound 3's estimate is 2.5-fold (0.40 log units) above it, within the range that was stated.
By their numbers in this assay, from the lowest: compounds 3 and 1 (each within the scatter of the next); then compound 2.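

In this assay the exchange of isopropoxy for isopropylamino on a carbonyl carbon gives a 2.4-fold lower number from compound 2 to compound 3 (0.38 log units; beyond the scatter) and so shows that the number at this place depends on the atom linking the isopropyl group to the carbonyl carbon, not only on the group carried there, which was all that the earlier step had varied. Read against the pentyl ester, the same amide gives a 1.2-fold lower number from compound 1 to compound 3 (0.07 log units; within the scatter) and thus places compound 3 level with compound 1, so in this small set the isopropyl group reaches the number of the pentyl ester once it is attached through nitrogen instead of oxygen. The data given offer nothing that accounts for either step.

The compounds shown leave open whether pentylamino on the same carbonyl carbon would give a lower number than isopropylamino, which would show whether the chain and the linking atom act independently or together. They also leave open how a carboxylic acid, or dimethylamino, which has no amide hydrogen, would read in this assay at this place on the shared core.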